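The compounds below may be only part of what the source reports. "The series", "measured", "known", "first", "only" and "open" are said of these compounds alone.

Compound 1 `O=c1n(Cc2cc3cnccc3n2CCCCF)c2cnccc2n1C1CC1`: in an ADME assay on HeLa cells (Homo sapiens) for cytotoxicity, read by ATP content, with a stated time of 3 days (a lower number here means that less compound is tolerated, a higher number that more compound is tolerated), this compound reaches only a limit, > 50000 nM.
Compound 2 `O=c1n(Cc2nc3cnccc3n2CCCCO)c2cnccc2n1C1CC1`: in this assay this compound also reaches only a limit, > 100000 nM.
Compound 3 `N#CCCCn1c(Cn2c(=O)n(-c3ccc(OC(F)(F)F)cc3)c3ccncc32)cc2cc(Cl)ccc21`: in this assay this compound likewise reaches only a limit, > 50000 nM.

None of the three measured compounds gives a number in this assay; each value is a limit of the assay, meaning the cells tolerated every concentration tried. Compound 1 sits at the limit of > 50000 nM in this assay, at which 2 of the 3 values shown sit, while the remaining value sits at the limit of > 100000 nM in this assay, at which 1 of the 3 values shown sits. Among the measured compounds shown here, no two measured compounds differ in only one place, so no measured step exists to lean on.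

Compound 4 `CS(=O)(=O)CCCn1c(Cn2c(=O)n(C3CC3)c3ccncc32)cc2cnccc21` has not yet been measured in this assay. It differs from compound 1 by methylsulfonyl in place of fluoromethyl on a saturated chain carbon, three bonds along the chain from an aromatic nitrogen. With no measured step and with every shown value at a limit, the expected step from compound 1 to compound 4 is a step that the limit leaves unreadable from compound 1 to compound 4, which is none beyond the usual scatter. Compound 4 is therefore expected to give about 80000 nM in this assay, with a range from 30000 nM to 300000 nM, and most likely again only a limit rather than a number.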

Compound 4, half-maximal cytotoxic concentration: > 50000 nM
Compound 4: no number, only a limit; the forecaster's own chance of this, stated with the estimate: 80%; the middle value lies beyond the limit too.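

In this assay compound 4 gives > 50000 nM, which is a limit and not a number. Compound 1 gives > 50000 nM, also a limit, so the step between these two compounds cannot be read. The compounds shown leave open what concentration of any of them harms the cells, and whether swapping fluoromethyl for methylsulfonyl changes that concentration at all; most values sit at one shared limit: the limit of > 50000 nM in this assay, at which 3 of the 4 values shown sit.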